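One more fluorine: from difluoromethoxy to trifluoromethoxy

This account rests on a few compounds, and the source may have more. Where it says the series, first, only, none or still open, it means among the compounds named here.

- Compound 1 `OC[C@H]1O[C@@H](n2cnc3c(NCc4ccccc4F)ncnc32)[C@H](O)[C@@H]1O` gives > 166000 nM (a limit, not a number)
- Compound 2 `OC[C@H]1O[C@@H](n2cnc3c(NCc4ccccc4OC(F)F)ncnc32)[C@H](O)[C@@H]1O` gives "not determined" (no result reported)

The measurements come from a functional assay on B16 cells (Mus musculus) for antiproliferative activity, with a stated time of 72 h (a higher number here means a weaker inhibitor, a lower number a stronger inhibitor), and they leave little to compare. Compound 1 gives > 166000 nM in this assay and this is a limit of the assay. Compound 2 has no result ("not determined" (no result reported)) and so has no place on the scale. The only mark on that scale is the limit of > 166000 nM in this assay, at which 1 of the 2 values shown sits, and it belongs to compound 1.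

Compound 3 `OC[C@H]1O[C@@H](n2cnc3c(NCc4ccccc4OC(F)(F)F)ncnc32)[C@H](O)[C@@H]1O` carries trifluoromethoxy where compound 2 carries difluoromethoxy. The change is fluoro in place of hydrogen on a saturated chain carbon bound to two fluorine atoms and an oxygen on an aromatic ring with fluoro in place of hydrogen on a saturated chain carbon bound to two fluorine atoms and an oxygen on an aromatic ring.

Because compound 1 stands at the limit > 166000 nM in this assay a weak result is expected here too, with no step beyond the usual scatter in either direction. For compound 3 the estimated half-maximal inhibitory concentration is 170000 nM (expected range 60000 nM to 300000 nM).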

Compound 3, half-maximal inhibitory concentration: > 166000 nM
Compound 3: only a limit was reported; the forecaster's own chance of this, stated with the estimate: 70%; the middle value does not contradict the limit.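

Compound 3 gives > 166000 nM in this assay, which is a limit and not a number. No new step can be read for compound 3, since compound 2 has no result and compound 1 shares the same mark: the limit of > 166000 nM in this assay, at which 2 of the 3 values shown sit. The compounds shown leave open whether trifluoromethoxy differs from difluoromethoxy here, and how strongly, if at all, any of them acts on these cells.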